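The source may hold more compounds than are shown below. What is called first, only, known or untested is meant among the compounds shown, and "the series" means these compounds.

Compound 1, `Nc1ncnc2c1c(-c1cnc3[nH]ccc3c1)nn2CCCCCCCCCC(=O)NO`, gives 8160 nM in a functional assay on SNU-423 cells (Homo sapiens) for inhibition, read by MTT assay, with a stated time of 72 h; a higher number here means a weaker inhibitor, a lower number a stronger inhibitor. Compound 2, `Nc1ncnc2c1c(-c1cnc3[nH]ccc3c1)nn2CCCCCCC(=O)NO`, gives 7500 nM. Compound 3, `Nc1nc2cc(-c3nn(CCCCCC(=O)NO)c4ncnc(N)c34)ccc2o1`, gives 12600 nM.

Compounds 1 and 2 share one core, while compound 3 carries another; the difference between the two cores is not broken down here. Compound 2 turns into compound 1 by 3-(hydroxycarbamoyl)propyl in place of hydroxycarbamoyl on a saturated chain carbon, six bonds along the chain from an aromatic nitrogen, and that step measured a 1.1-fold higher number from compound 2 to compound 1 (0.04 log units; within the scatter). Compound 4, `Nc1nc2cc(-c3nn(CCCCCCCCC(=O)NO)c4ncnc(N)c34)ccc2o1`, is not yet measured and arises from compound 3 by 3-(hydroxycarbamoyl)propyl in place of hydroxycarbamoyl on a saturated chain carbon, five bonds along the chain from an aromatic nitrogen. This is the same kind of change, not the same one: in compound 2 the saturated chain carbon sits six bonds along the chain from an aromatic nitrogen, in compound 3 five bonds along the chain. Because a 1.1-fold higher number from compound 2 to compound 1 (0.04 log units; within the scatter) stayed within the scatter, compound 4 is expected to stay close to compound 3, with an estimated step of a 1.1-fold lower number from compound 3 to compound 4 (0.02 log units; within the scatter). Compound 4 is therefore estimated at 12000 nM, expected to lie between 6000 nM and 25000 nM.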

Compound 4, half-maximal inhibitory concentration: 4940 nM
Compound 4: the middle estimate sits 2.4-fold (0.39 log units) above what was measured; the measured number lies below the stated range.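

Putting 3-(hydroxycarbamoyl)propyl in place of hydroxycarbamoyl gave a 2.6-fold lower number from compound 3 to compound 4 (0.41 log units; beyond the scatter) in this assay, a modest gain in strength on this core. The same kind of change therefore did not carry over with the same size from one core to the other: the same change on two cores in this assay, a 1.1-fold higher number (0.04 log units; within the scatter) from compound 2 to compound 1 and a 2.6-fold lower number (0.41 log units; beyond the scatter) from compound 3 to compound 4, 2.8-fold (0.44 log units) apart, beyond the scatter of two such steps This rests on a single pair for each core, and the change sits at a different place along the chain in each pair, so it gives neither a reason for the gap nor a rule for other cores.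

The compounds shown leave open what a still longer chain would do on either core. They also leave open whether a carboxylic acid or an amine could stand in place of the hydroxycarbamoyl end.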